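Swapping Chlorines for Methyls on the Aryl Ring

The source may hold more compounds than are shown below. What is called first, only, known or untested is meant among the compounds shown, and "the series" means these compounds.

Of the compounds shown here, three sharing one core have been tested in a functional assay (muscle tissue) with Cavia porcellus as the target; on this read-out higher numbers stand for an effect only at larger amounts of compound and lower numbers for an effect already at smaller amounts. Compound 2 `COC(=O)C1=C(C)N=C(C)/C(=C(\O)OC)C1c1cc(Cl)cc(Cl)c1` gives 93.3 nM, the lowest number of the three. Compound 1 `COC(=O)C1=C(C)N=C(C)/C(=C(\O)OC)C1c1ccccc1N` gives 39800 nM in this assay, and compound 3 `COC(=O)C1=C(C)N=C(C)/C(=C(\O)OC)C1c1cc(OC)c(OC)cc1OC` gives 1000000 nM in this assay. Among the measured compounds shown here, the only single-point comparison available is a 430-fold lower number from compound 1 to compound 2 (2.63 log units; beyond the scatter), which shows how strongly the group on the saturated ring carbon sets the read-out. Compound 4 `COC(=O)C1=C(C)N=C(C)/C(=C(\O)OC)C1c1cc(C)ccc1C` has not yet been measured; it differs from compound 2 in one place: 2,5-dimethylphenyl in place of 3,5-dichlorophenyl on a saturated ring carbon. For the measured compounds named here, no measured step exchanges a chlorinated ring for a methylated one, so the guidance is indirect: the large step from compound 1 to compound 2, and the much higher number of compound 3 set beside that of compound 2, say that the aryl ring matters greatly and that compound 2 holds the best number seen. Leaving the 3,5-dichlorophenyl is therefore expected to cost something, though less than the swaps seen so far. Compound 4 is estimated to give 1000 nM in this assay, plausibly within 150 nM to 10000 nM, meaning an expected step of an 11-fold higher number from compound 2 to compound 4 (1.03 log units; beyond the scatter).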

Compound 4, half-maximal effective concentration: 100 nM
Compound 4: middle estimate off by 10-fold (1.00 log units), on the high side, outside the stated range (below it).
By their numbers in this assay, from the lowest: compounds 2 and 4 (each within the scatter of the next); then compound 1; then compound 3.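

In this assay, 2,5-dimethylphenyl in place of 3,5-dichlorophenyl on the saturated ring carbon gives a 1.1-fold higher number from compound 2 to compound 4 (0.03 log units; within the scatter), so at this position two methyl groups can stand in for two chlorines with no difference that can be told from the scatter. A ring without chlorine thus reads like compound 2, and a 400-fold lower number from compound 1 to compound 4 (2.60 log units; beyond the scatter) shows that compound 4 keeps the large distance from the 2-aminophenyl ring of compound 1. Nothing available explains why these two rings read alike, so no cause can be given. Going by these compounds, it remains open whether a plain phenyl ring or a ring bearing trifluoromethyl or nitro groups would read the same way. On these data alone, it is also open whether 2,5-dichlorophenyl, with chlorines in the places where compound 4 has its methyl groups, would match compound 4.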